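Replacing an aromatic sulfonyl group with a saturated ring

The source may hold more compounds than are shown below. What is called first, only, known or untested is meant among the compounds shown, and "the series" means these compounds.

Compound 1 `O=C(NCc1ccc(S(=O)(=O)c2cccc(C(F)(F)F)c2)cc1)N1Cc2ccncc2C1`: 8 nM
Compound 2 `O=C(NCc1ccc(S(=O)(=O)c2cncc(C(F)(F)F)c2)cc1)N1Cc2ccncc2C1`: 15 nM
Compound 3 `O=C(NCc1ccc(S(=O)(=O)C2CCN(C3COC3)CC2)cc1)N1Cc2ccncc2C1`: 31 nM

In an assay on isolated protein for inhibition of Nicotinamide phosphoribosyltransferase (Homo sapiens), read by mass spectrometry, with stated times of 15 min and 30 min (on this read-out higher numbers stand for weaker inhibition and lower numbers for stronger inhibition), compound 2 stands second highest of three numbers; its number sits within the scatter of compound 1 and beyond the scatter, on the lower side, of compound 3 (a 2.1-fold higher number from compound 2 to compound 3 (0.32 log units; beyond the scatter)).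

Compound 4 `O=C(NCc1ccc(S(=O)(=O)N2CCC[C@H](O)C2)cc1)N1Cc2ccncc2C1` changes the same place: 3-hydroxypiperidin-1-yl in place of 5-(trifluoromethyl)pyridin-3-yl on a sulfonyl sulfur

Within the data shown here, two measured steps bear on this, both swapping an aromatic ring on the sulfonyl sulfur for a saturated six-membered ring: a 2.1-fold higher number from compound 2 to compound 3 (0.32 log units; beyond the scatter) and a 3.9-fold higher number from compound 1 to compound 3 (0.59 log units; beyond the scatter). Both moved the number modestly higher. A step of similar size and direction is therefore expected here, a 2.7-fold higher number from compound 2 to compound 4 (0.43 log units; beyond the scatter). Compound 4 is estimated at 40 nM, with a range from 15 nM to 120 nM.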

Compound 4, half-maximal inhibitory concentration: 770 nM
Compound 4: the middle estimate sits 19-fold (1.28 log units) below what was measured, outside the stated range (above it).
By their numbers in this assay, from the lowest: compounds 1 and 2 (each within the scatter of the next); then compound 3; then compound 4.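

In this assay, among these compounds, this position proves far less tolerant than the earlier compounds suggested: 3-hydroxypiperidin-1-yl gives a 51-fold higher number from compound 2 to compound 4 (1.71 log units; beyond the scatter) and a 96-fold higher number from compound 1 to compound 4 (1.98 log units; beyond the scatter). A saturated six-membered ring on the sulfonyl sulfur does not by itself set the size of the step, as compound 3 also carries one, yet the change gives a 25-fold higher number from compound 3 to compound 4 (1.40 log units; beyond the scatter). Nothing measured here explains this loss.

The compounds shown leave open whether the hydroxyl or the piperidin-1-yl ring accounts for it. A plain piperidin-1-yl group, or a methoxy group in place of the hydroxyl, would help separate the two.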